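This account rests on a few compounds, and the source may have more. Where it says the series, first, only, none or still open, it means among the compounds named here.

Measured compounds in a functional assay on KG-1 cells (Homo sapiens) for antiproliferative activity; a lower number here means that less compound is needed, a higher number that more compound is needed for the effect:

compound 1 `NC(=O)c1cc(Cl)c2c(Cl)c(C#CCCO)n([C@H]3CCCNC3)c2n1`, 56 nM
compound 2 `CN1CC(C#Cc2c(Cl)c3c(Cl)cc(C(N)=O)nc3n2[C@H]2CCCNC2)CC1=O`, 155 nM
compound 3 `CC(C)(O)C#Cc1c(Cl)c2c(Cl)cc(C(N)=O)nc2n1[C@H]1CCCNC1`, 302 nM

Compound 1 holds the lowest number of the three; the steps to compound 2 and to compound 3 both lie beyond the scatter, so on these numbers compound 1 is the most active of the set.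

Compound 4 `COC(C)(C)CC#Cc1c(Cl)c2c(Cl)cc(C(N)=O)nc2n1[C@H]1CCCNC1` is not yet measured. It differs from compound 1 only at the end of the alkyne chain: 1-methoxy-1-methylethyl in place of hydroxymethyl on a saturated chain carbon bound to a triple-bonded carbon. Both earlier changes at the same chain end bear on this step. Replacing the 2-hydroxyethyl group gave a 2.8-fold higher number from compound 1 to compound 2 (0.44 log units; beyond the scatter) and a 5.4-fold higher number from compound 1 to compound 3 (0.73 log units; beyond the scatter); each change away from compound 1 at this position raised the number by a modest amount. Compound 4 again alters the 2-hydroxyethyl end, so a modest rise in this assay is the expected outcome rather than no change or a fall. For compound 4 the expected step is a 3.2-fold higher number from compound 1 to compound 4 (0.51 log units; beyond the scatter). Compound 4 is therefore estimated at 180 nM, with a range from 70 nM to 500 nM.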

Compound 4, half-maximal effective concentration in the KG-1 assay: 172 nM
The estimate for compound 4 lay 1.0-fold (0.02 log units) above the measured number; the range from low to high includes it.
By their numbers in the KG-1 assay, from the lowest: compound 1; then compounds 2, 4 and 3 (each within the scatter of the next).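

In the KG-1 assay, 2-methoxy-2-methylpropyl, with 0 hydrogen-bond donors, gives a 3.1-fold higher number from compound 1 to compound 4 (0.49 log units; beyond the scatter), so a chain end without a donor falls in the same band as the earlier replacements: a 1.1-fold higher number from compound 2 to compound 4 (0.05 log units; within the scatter), and a 1.8-fold lower number from compound 3 to compound 4 (0.24 log units; within the scatter). Compound 3 keeps a hydroxyl in 1-hydroxy-1-methylethyl, yet compound 4 cannot be told apart from it, so the presence of a hydroxyl alone does not recover the number of compound 1. In a physicochemical assay for solubility, measured as thermodynamic solubility, at pH 7.4 (on this read-out higher numbers stand for higher solubility and lower numbers for lower solubility), compound 1 gives 144000 nM and compound 4 gives 1200 nM. Set against that modest step, the same change weighs far more in the physicochemical assay: the measured solubility of compound 1, 144000 nM, and of compound 4, 1200 nM, a 120-fold lower number (2.08 log units; beyond the scatter)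

A 2-methoxyethyl end would separate the loss of the hydroxyl from the added methyl groups. From the compounds shown here alone, whether a primary amine at this chain end could keep the number of compound 1 in the KG-1 assay and also hold up in the physicochemical assay remains open.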